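A few compounds are considered here, and "the series" means these few. Any claim that something is new, unique, unknown or untested is made for them only; others in the source may bear on it.

Measured compounds in the series:

compound 1, `S=c1[nH]nc(-c2ccc3c(c2)OCCO3)o1` — 10600 nM
compound 2, `FC(F)(F)c1ccccc1NCn1nc(-c2ccc3c(c2)OCCO3)oc1=S` — 9220 nM
compound 3, `S=c1oc(-c2ccc3c(c2)OCCO3)nn1CNc1cccc(Cl)c1` — 6220 nM

All three were run in a functional assay, with a stated time of 6 min; a higher number here means a weaker inhibitor, a lower number a stronger inhibitor. Compound 1, which carries the shared core without a substituent on the ring nitrogen, gives 10600 nM in this assay. Compound 2 gives 9220 nM and compound 3 gives 6220 nM. Compound 3 has the lowest of the three numbers, but its gap to compound 2 and its gap to compound 1 both fall within the scatter of repeat measurements, so the three compounds are not separated from one another in this assay; no ranking among them is supported.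

The next compound to be measured is compound 4, `O=[N+]([O-])c1ccc(NCn2nc(-c3ccc4c(c3)OCCO4)oc2=S)cc1`. It differs from compound 3 by 4-nitrophenyl in place of 3-chlorophenyl on an amine nitrogen. Going by the values given here, no step between two measured compounds isolates a change of this kind, and the three measured compounds, which differ from one another more widely, sit within the scatter. On that basis the step from compound 3 to compound 4 in this assay is expected to be small, with no direction favoured and nothing beyond the scatter expected: a 1.0-fold lower number from compound 3 to compound 4 (0.02 log units; within the scatter). Compound 4 is accordingly estimated at 6000 nM, with a range from 2500 nM to 15000 nM.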

Compound 4, half-maximal inhibitory concentration: 9950 nM
The estimate for compound 4 lay 1.7-fold (0.22 log units) below the measured number, within the range that was stated.
By their numbers in this assay, from the lowest: compounds 3, 2, 4 and 1 (each within the scatter of the next).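

The series now holds its first comparison that changes one place only: in this assay, 4-nitrophenyl in place of 3-chlorophenyl on the amine nitrogen gives a 1.6-fold higher number from compound 3 to compound 4 (0.20 log units; within the scatter) and so leaves the two compounds unseparated. Going by these compounds alone, at this position, then, exchanging one aromatic ring for another with a different substituent, and with hydrogen-bond acceptors entering alongside it, produces no step that can be told from repeat scatter, which the earlier compounds, differing in more than one place, could not show. No measurement is available that bears on the reason for this result.

Within the data shown here, this single step covers only two substituted phenyl groups, so it remains open whether any group on this amine nitrogen can move the number in this assay beyond the scatter. A saturated ring such as cyclohexyl, a basic amine such as piperidine or a carboxylic acid on the phenyl ring would test this position more widely than the pair in hand.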